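The source may hold more compounds than are shown below. What is called first, only, known or untested is meant among the compounds shown, and "the series" means these compounds.

Compound 2 `N#Cc1ccc(-c2nc3ccccn3c2Sc2ccccc2)cc1` was tested in a functional assay on HeLa cells (Homo sapiens) for inhibition, read by MTT assay, with a stated time of 48 h (on this read-out higher numbers stand for weaker inhibition and lower numbers for stronger inhibition), and gave 64200 nM. Among the measured compounds shown here, of the two numbers in hand this is the higher one, but its only neighbour, compound 1 `C(=C/c1nc2ccccn2c1Sc1ccccc1)\c1ccccc1`, with 35500 nM in this assay, sits close enough that no order between the two can be read from the data. For the measured compounds named here, the one step between measured compounds, a 1.8-fold higher number from compound 1 to compound 2 (0.26 log units; within the scatter), replaces the 2-phenylethenyl group with 4-cyanophenyl and does not leave the scatter.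

Compound 3 `Clc1ccc(-c2nc3ccccn3c2Sc2ccccc2)cc1` differs from compound 2 in a single place: chloro in place of cyano on an aromatic carbon. Going by the values given here, no measured pair shows this exchange, so the only guide is the general experience that the one step seen so far, from compound 1 to compound 2, stayed within the scatter while a larger piece of the molecule was swapped. On that basis compound 3 is expected to stay near compound 2, with the step of a 1.3-fold lower number from compound 2 to compound 3 (0.11 log units; within the scatter) estimated to remain within the scatter and in no fixed direction. The estimate for compound 3 in this assay is 50000 nM, with a range from 20000 nM to 150000 nM.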

Compound 3, half-maximal inhibitory concentration: 62000 nM
Estimate against measurement, compound 3: 1.2-fold (0.09 log units) below; measured number inside the range.
By their numbers in this assay, from the lowest: compounds 1, 3 and 2 (each within the scatter of the next).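

In this assay, among the compounds shown here, the exchange of cyano for chloro on an aromatic carbon of a six-membered aromatic ring of carbon only, para to a large group, comes to a 1.0-fold lower number from compound 2 to compound 3 (0.02 log units; within the scatter) and is the first exchange seen at this place itself. The earlier step had replaced the whole group, whereas this one leaves the phenyl ring in place and shows that cyano and chloro at this place cannot be told apart on this read-out. The 4-chlorophenyl group also gives a 1.7-fold higher number from compound 1 to compound 3 (0.24 log units; within the scatter) against the 2-phenylethenyl group, so all three compounds lie within the scatter of one another, and nothing at hand gives a reason for this or bears on the result.

The compounds shown leave open whether any group at this place can move the number beyond the scatter, for instance an amine, a carboxylic acid or a methoxy group. They also leave open what a change elsewhere would do, since the rest of the shared core is the same in compound 2 and compound 3.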